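The source may hold more compounds than are shown below. What is called first, only, known or untested is meant among the compounds shown, and "the series" means these compounds.

Measured so far:
- compound 1, `O=S(=O)(Nc1cc(-c2cnc3[nH]cc(-c4ccccc4)c3c2)cnc1Cl)c1ccccc1` — 1520 nM
- compound 2, `O=S(=O)(Nc1cc(-c2cnc3[nH]cc(-c4ccncc4)c3c2)cnc1Cl)c1ccc(F)cc1` — 410 nM

Of the compounds shown here, two from this series have been tested in a functional assay on Pfeiffer cells (Homo sapiens) for inhibition, read by CCK-8 assay; on this read-out lower numbers stand for stronger inhibition of growth and higher numbers for weaker inhibition of growth. Compound 1 gives 1520 nM, and compound 2 gives 410 nM. Among the measured compounds shown here, of the two numbers, compound 2 stands at the lower one; its only neighbour is compound 1, whose number is higher by a gap that lies beyond the usual scatter. For the measured compounds named here, no single-point step between measured compounds is available, since compound 1 and compound 2 differ in more than one place.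

The next compound, compound 3, `O=S(=O)(Nc1cc(-c2cnc3[nH]cc(-c4ccncc4)c3c2)cnc1Cl)c1ccccc1`, is drawn from compound 2 by one change: hydrogen in place of fluoro on an aromatic carbon, para to a large group. Nothing measured isolates this change, so the expectation rests only on the value of compound 2 and on the change being a single small removal with no ring, donor or acceptor involved. The step from compound 2 to compound 3 in this assay is expected to be small, if anything a modest move toward a higher number, quite possibly within the scatter. Compound 3 is estimated at 650 nM, within 250 nM to 1700 nM, corresponding to a 1.6-fold higher number from compound 2 to compound 3 (0.20 log units; within the scatter).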

Compound 3, concentration for 50% growth inhibition: 100 nM
Estimate against measurement, compound 3: 6.5-fold (0.81 log units) above; the measured number lies below the stated range.
By their numbers in this assay, from the lowest: compound 3; then compound 2; then compound 1.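

In this assay, hydrogen in place of fluoro on the phenylsulfonyl ring, para to a large group, gives a 4.1-fold lower number from compound 2 to compound 3 (0.61 log units; beyond the scatter) and is beyond the scatter, so this place responds to a single-atom change, and with pyridin-4-yl on the core, phenylsulfonyl goes with stronger inhibition of growth than (4-fluorophenyl)sulfonyl. The earlier pair could not show this, as compound 1 and compound 2 differ in more than one place; compound 3 now also isolates the other change, where pyridin-4-yl in place of phenyl gives a 15-fold lower number from compound 1 to compound 3 (1.18 log units; beyond the scatter) and is the larger of the two steps. Nothing at hand accounts for either step.

Open, going by these compounds, is whether chloro, methyl or methoxy at this same place would read like fluoro or like hydrogen, and how an amine or a carboxylic acid there would read in this assay. Also open, on these data alone, is whether the step from fluoro to hydrogen keeps its direction and size with phenyl in place of pyridin-4-yl on the core, as each step is known from one pair only.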